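Ethoxy to butoxy on compound 3

The compounds below may be only part of what the source reports. "The series", "measured", "known", "first", "only" and "open" are said of these compounds alone.

In a functional assay on the whole organism with Rattus norvegicus as the target (a higher number here means that more compound is needed for the effect, a lower number that less compound is needed), compound 3 (`CCOC(=O)C(=O)Nc1nc(-c2ccc(C(=O)OCC)cc2)cs1`) gives > 10 mg/kg as a limit and not a number. Compound 1 (`CCOC(=O)C(=O)Nc1nc(-c2ccc(F)cc2)cs1`) gives > 10 mg/kg which is also a limit. Compound 2 (`CCOC(=O)c1ccc(-c2csc(NC(=O)C(=O)OC)n2)cc1`) gives > 10 mg/kg which is again a limit. The series therefore stands at the limit of > 10 mg/kg in this assay, at which 3 of the 3 values shown sit, with no number yet. Compound 4 (`CCCCOC(=O)C(=O)Nc1nc(-c2ccc(C(=O)OCC)cc2)cs1`) carries ethyl in place of hydrogen on a saturated chain carbon, two bonds along the chain from an oxygen next to a carbonyl group. Only a step that the two limits leave unreadable from compound 2 to compound 3 concerns this chain, and a step that the two limits leave unreadable from compound 1 to compound 3 concerns another group. Neither gives a size or a direction, so no step beyond the scatter is expected, and another limit is the likeliest report. The expected change is a step that the limit leaves unreadable from compound 3 to compound 4 in this assay on this thin basis. For compound 4 the estimate is 15 mg/kg with an expected range from 6 mg/kg to 40 mg/kg if a number is reported.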

Compound 4, dose for half-maximal effect: > 10 mg/kg
Compound 4: only a limit was reported; the forecaster's own chance of this, stated with the estimate: 80%; the middle value lies beyond the limit too.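

Compound 4 gives > 10 mg/kg in this assay, a limit and not a number, so the steps from compound 3 and from compound 2 to compound 4 cannot be read. The compounds shown leave open whether changing this chain affects the dose needed at all, as the series stands at one limit: the limit of > 10 mg/kg in this assay, at which 4 of the 4 values shown sit.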